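The compounds below may be only part of what the source reports. "The series", "measured", "known", "first", "only" and "open" are said of these compounds alone.

Measured in a functional assay on KB cells (Homo sapiens) for inhibition, read by sulforhodamine B assay, with a stated time of 72 h; a lower number here means a stronger inhibitor of growth, a higher number a weaker inhibitor of growth:

Compound 1 `NNC(=O)CCc1ccncc1-c1ccc2ccccc2c1`: > 10000 nM, a limit.
Compound 2 `CNC(=O)/C=C/c1ccncc1-c1ccc2cc[nH]c2c1`: > 10000 nM, a limit.
Compound 3 `COC1CN(C(=O)/C=C/c2ccncc2-c2ccc3ccccc3c2)C1`: > 10000 nM, a limit.

Compound 3 has no numerical value, only the limit of the assay. The whole set gives no number to work from: the limit of > 10000 nM in this assay, at which 3 of the 3 values shown sit. Among the compounds with values here, no step between measured compounds can therefore be read from the data.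

The next compound is compound 4 `O=C(/C=C/c1ccncc1-c1ccc2ccccc2c1)NC1CC1`. In it, cyclopropylamino takes the place of 3-methoxyazetidin-1-yl on a carbonyl carbon: cyclopropylamino in place of 3-methoxyazetidin-1-yl on a carbonyl carbon.

Compound 2 also carries the amide hydrogen and still gives > 10000 nM, which is a limit. Nothing in the set therefore points to a gain from this change, and no step beyond the scatter is expected in this assay. The expected change is a number no higher from compound 3 to compound 4 (the limit leaves the size open), and another limit reading is the likeliest outcome. For compound 4 the estimated value is 10000 nM, with an expected range of 4000 nM to 20000 nM.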

Compound 4, concentration for 50% growth inhibition: 6050 nM
Compound 4: the middle estimate sits 1.7-fold (0.22 log units) above what was measured; measured number inside the range.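

In this assay, at the carbonyl carbon, cyclopropylamino in place of 3-methoxyazetidin-1-yl gives an at least 1.6-fold lower number from compound 3 to compound 4 (0.21 log units; that floor lies within the scatter). The wider change, 2-(cyclopropylcarbamoyl)ethenyl in place of 2-(aminocarbamoyl)ethyl on an aromatic carbon, gives an at least 1.6-fold lower number from compound 1 to compound 4 (0.21 log units; that floor lies within the scatter). Both steps are floors, so their true size stays open, but compound 4 is now the only compound shown with a number rather than a limit: the limit of > 10000 nM in this assay, at which 3 of the 4 values shown sit.

The compounds shown do not separate the contribution of the amide hydrogen from that of the three-membered carbon ring. Also open, on these data alone, is how cyclobutylamino, dimethylamino or a longer alkylamino chain on the same carbonyl carbon would read, and whether any such group would give a step beyond the scatter.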